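The compounds below may be only part of what the source reports. "The series", "measured", "known", "first", "only" and "open" are said of these compounds alone.

Measured compounds:
- compound 1 `COC(=O)CCCCCOc1cc(-c2ccccc2)cc(-c2ccccc2)n1`, in an assay for binding affinity to leukotriene B4 receptor 1 (Homo sapiens) (a lower number here means a stronger inhibitor, a higher number a weaker inhibitor), compound 1 gives 100 nM
- compound 2 `O=C(O)CCCCOc1cc(-c2ccccc2)cc(-c2ccccc2)n1`, in this assay compound 2 gives 300 nM
- compound 3 `CC(C)(CCCCCCOc1cc(-c2ccccc2)cc(-c2ccccc2)n1)C(=O)O`, in this assay compound 3 gives 60 nM

Compound 3 has the lowest of the three numbers. Its nearest neighbour is compound 1, and the difference between compound 1 and compound 3 is within the scatter, so the two cannot be ordered; compound 2 stands furthest away, with a 5.0-fold lower number from compound 2 to compound 3 (0.70 log units; beyond the scatter).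

Compound 4 `NC(=O)CCCCCOc1cc(-c2ccccc2)cc(-c2ccccc2)n1` is the next compound to be measured. It differs from compound 3 in one place: carbamoyl in place of 2-carboxy-2-methylpropyl on a saturated chain carbon, five bonds along the chain from an oxygen on an aromatic ring.

Two of the measured steps bear on this change. The step of a 1.7-fold lower number from compound 1 to compound 3 (0.22 log units; within the scatter) shows that exchanging a methoxycarbonyl at this position for the longer 2-carboxy-2-methylpropyl moves the number only within the scatter, while a 3.0-fold higher number from compound 1 to compound 2 (0.48 log units; beyond the scatter) shows that going to a shorter free acid weakens binding modestly. Going by the values given here, compound 4 keeps the chain length of compound 1 but carries a carbamoyl instead of the methoxycarbonyl, for which no measured step exists. Compound 4 is therefore expected to show a 3.3-fold higher number from compound 3 to compound 4 (0.52 log units; beyond the scatter), a modest weakening in this assay. The estimate for compound 4 in this assay is 200 nM, within a range from 60 nM to 700 nM.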

Compound 4, half-maximal inhibitory concentration: 150 nM
Estimate against measurement, compound 4: 1.3-fold (0.12 log units) above, and the stated range covers the measured number.
By their numbers in this assay, from the lowest: compounds 3, 1, 4 and 2 (each within the scatter of the next, the first and the last beyond it).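

In this assay, carbamoyl in place of 2-carboxy-2-methylpropyl gives a 2.5-fold higher number from compound 3 to compound 4 (0.40 log units; beyond the scatter), a modest step, which shows that the group at this place can separate compounds that the exchange from methoxycarbonyl to 2-carboxy-2-methylpropyl could not. Amino in place of methoxy on a carbonyl carbon gives a 1.5-fold higher number from compound 1 to compound 4 (0.18 log units; within the scatter), and carbamoylmethyl in place of carboxy gives a 2.0-fold lower number from compound 2 to compound 4 (0.30 log units; within the scatter), so compound 4 cannot be ordered against either compound 1 or compound 2, even though compound 2 and compound 3 lie beyond the scatter of each other. The result thus places the carbamoyl among the groups tried at this chain end without setting it clearly apart from the methyl ester or the shorter free acid, and no data shown account for any of these steps.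

The compounds shown leave open how a plain carboxylic acid on the chain of compound 4 would compare, with neither the added chain length nor the two methyl groups of compound 3. They also leave open whether an amine or a nitrile at this chain end, or a longer chain ending in carbamoyl, would behave like compound 4.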